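The compounds below may be only part of what the source reports. "The series", "measured", "known", "first", "only" and "open" are said of these compounds alone.

Measured compounds in a functional assay on HepG2 cells (Homo sapiens) for cytotoxicity, read by MTT assay, with a stated time of 48 h; a lower number here means a stronger inhibitor, a higher number a weaker inhibitor:

Compound 1, `Cc1ccc(/C=C2/S/C(=N/c3ccccc3)N(Cc3ccncc3)C2=O)cc1`: compound 1 gives 19700 nM.
Compound 2, `O=C1/C(=C\c2ccc(Cl)cc2)S/C(=N/c2ccccc2)N1Cc1ccncc1`: compound 2 gives 28800 nM.
Compound 3, `O=C1/C(=C\c2cccc(Cl)c2)S/C(=N/c2ccccc2)N1Cc1ccncc1`: compound 3 gives 28900 nM.

Compound 2 sits among three numbers that all lie within the scatter of one another: its nearest neighbour is compound 3, a 1.0-fold higher number from compound 2 to compound 3 (0.00 log units; within the scatter), and the further pair gives a 1.5-fold higher number from compound 1 to compound 2 (0.16 log units; within the scatter). For the measured compounds named here, the third pair, a 1.5-fold higher number from compound 1 to compound 3 (0.17 log units; within the scatter), is likewise within the scatter, so on the numbers so far nothing is separated from anything else.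

Compound 4, `O=C1/C(=C\c2ccccn2)S/C(=N/c2ccccc2)N1Cc1ccncc1`, has not yet been run in this assay. Relative to compound 2 the change is pyridin-2-yl in place of 4-chlorophenyl on a double-bonded chain carbon bound to a double-bonded ring carbon.

Going by the values given here, two measured steps touch the same place: a 1.5-fold higher number from compound 1 to compound 2 (0.16 log units; within the scatter), a substituent swap on the ring, and a 1.0-fold higher number from compound 2 to compound 3 (0.00 log units; within the scatter), a change of the ring's substitution pattern. Both are within the scatter. Among the compounds with values here, no measured step, however, replaces the carbon-only ring with a ring carrying a hetero atom, so that part of the change is unanchored. The working expectation is that the value for compound 4 stays near compound 2, with a step of a 1.0-fold lower number from compound 2 to compound 4 (0.01 log units; within the scatter) expected, that is, none beyond the scatter. The estimated value for compound 4 is 28000 nM, with a range from 11000 nM to 70000 nM.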

Compound 4, half-maximal inhibitory concentration: 31000 nM
Compound 4: middle estimate off by 1.1-fold (0.04 log units), on the low side; the measured number falls inside the stated range.
By their numbers in this assay, from the lowest: compounds 1, 2, 3 and 4 (each within the scatter of the next).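

At the position on a double-bonded chain carbon bound to a double-bonded ring carbon, the first ring with a hetero atom, pyridin-2-yl, keeps the number in this assay within the scatter of all three carbon-only rings (a 1.1-fold higher number from compound 2 to compound 4 (0.03 log units; within the scatter); a 1.1-fold higher number from compound 3 to compound 4 (0.03 log units; within the scatter); a 1.6-fold higher number from compound 1 to compound 4 (0.20 log units; within the scatter)). Across the compounds shown, this place therefore accepts a six-membered aromatic ring with 1 hetero atom and 1 hydrogen-bond acceptor, in place of a carbon-only ring with none, without a step beyond the scatter. No measured evidence accounts for this result.

On these data alone, whether the position of the ring nitrogen matters remains open, as pyridin-3-yl and pyridin-4-yl do not appear here. Also open, as far as these compounds go, is whether a phenyl ring carrying a carboxylic acid or an amine at this place would separate from the series.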